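The compounds below may be only part of what the source reports. "The series", "measured", "known", "first", "only" and "open" are said of these compounds alone.

Three compounds share one core, and the first of them, compound 1 `N=C(Nc1cccc(C(F)(F)F)c1)c1cc2c(-c3ccccc3)n[nH]c2cn1`, carries a trifluoromethyl group on the aniline ring. In a functional assay on PC-3 cells (Homo sapiens) for cytotoxicity, read by MTT assay, with a stated time of 72 h (a higher number here means a weaker inhibitor, a lower number a stronger inhibitor), compound 1 gives 19900 nM. Compound 2 `COc1ccc(Cn2nc(-c3ccccc3)c3cc(C(=N)Nc4ccccc4)ncc32)cc1` instead bears a 4-methoxybenzyl group on the ring nitrogen of the core, and in this assay compound 2 gives 6300 nM. Compound 3 `N=C(Nc1ccccc1)c1cc2c(-c3ccccc3)n[nH]c2cn1` has hydrogen at both of those places, and in this assay compound 3 gives 23000 nM, the highest of the three numbers. The step of a 1.2-fold higher number from compound 1 to compound 3 (0.06 log units; within the scatter) lies within the scatter, whereas the step of a 3.7-fold higher number from compound 2 to compound 3 (0.56 log units; beyond the scatter) is modest but real.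

Compound 4 `CN1CCN(c2ccc(NC(=N)c3cc4c(-c5ccccc5)n[nH]c4cn3)cc2)CC1` differs from compound 3 in one place: 4-methylpiperazin-1-yl in place of hydrogen on an aromatic carbon. For the measured compounds named here, no measured step places a group at exactly this position, so the guidance is indirect. Going by the values given here, the only change made on the same aniline ring, from compound 1 to compound 3, stayed within the scatter, which suggests that substituents on this ring have had little effect here; the larger step involved a different site. On that basis the expected step of a 1.8-fold lower number from compound 3 to compound 4 (0.25 log units; within the scatter) is small, with perhaps a slight lean toward a lower number. Compound 4 is therefore estimated at 13000 nM, within a range from 4500 nM to 38000 nM.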

Compound 4, half-maximal inhibitory concentration: 17100 nM
Beside the measured number, compound 4's estimate is 1.3-fold (0.12 log units) below it; the range from low to high includes it.
By their numbers in this assay, from the lowest: compound 2; then compounds 4, 1 and 3 (each within the scatter of the next).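

Adding 4-methylpiperazin-1-yl, a group of 7 heavy atoms with its own non-aromatic ring, on an aromatic carbon para to a large group gives a 1.3-fold lower number from compound 3 to compound 4 (0.13 log units; within the scatter), so compound 3 and compound 4 cannot be told apart in this assay. For the compounds shown here, until now, the only substituent compared on this six-membered aromatic ring was trifluoromethyl, with a 1.2-fold higher number from compound 1 to compound 3 (0.06 log units; within the scatter); the new result extends this picture to a much larger group containing a ring, while the only step beyond the scatter remains a 3.7-fold higher number from compound 2 to compound 3 (0.56 log units; beyond the scatter), at a different site. Nothing measured here explains why the piperazine-bearing group leaves the number within the scatter of compound 3.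

From the compounds shown here alone, it remains open whether a group of a different kind on this same carbon, such as a carboxylic acid, a morpholine ring or a simple dimethylamino group, would also stay within the scatter. Going by these compounds alone, it is also open whether 4-methylpiperazin-1-yl and 4-methoxybenzyl would give a different number when carried together on one compound, since each has been seen only on its own.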